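Replacing a Chlorophenyl with a Bromophenyl: Cytotoxicity Expectations

This account rests on a few compounds, and the source may have more. Where it says the series, first, only, none or still open, it means among the compounds named here.

Three compounds have been measured in an ADME assay on NHDF cells (Homo sapiens) for cytotoxicity, read by MTT assay, with a stated time of 72 h; on this read-out lower numbers stand for stronger inhibition and higher numbers for weaker inhibition:

Compound 1 `COc1cccc(/C=C2\CCC/C(=C\c3ccc(Cl)cc3)C2=O)c1OC`: 18600 nM
Compound 2 `COc1cccc(/C=C2\CCC/C(=C\c3ccccc3Br)C2=O)c1OC`: > 50000 nM, which is a limit of the assay rather than a number
Compound 3 `COc1ccc(/C=C2\CCC/C(=C\c3ccc(Cl)cc3)C2=O)cc1OC`: 11200 nM

In this assay compound 1 gives 18600 nM. Compound 2 reaches only > 50000 nM, a limit of the assay and not a measured number. The change between them is 2-bromophenyl in place of 4-chlorophenyl on a double-bonded chain carbon bound to a double-bonded ring carbon, and it brings an at least 2.6-fold higher number from compound 1 to compound 2 (0.42 log units; beyond the scatter); the step can only be given as a lower bound because of the limit of > 50000 nM in this assay, at which 1 of the 3 values shown sits.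

Compound 3 carries the same atoms as compound 1, joined differently; how the two cores differ is not broken down here. In this assay compound 3 gives 11200 nM, and its number and that of compound 1 lie within the usual scatter of each other, so no order between them can be stated.

Compound 4 `COc1ccc(/C=C2\CCC/C(=C\c3ccccc3Br)C2=O)cc1OC` has not yet been measured. It stands to compound 3 as compound 2 stands to compound 1: the change is 2-bromophenyl in place of 4-chlorophenyl on a double-bonded chain carbon bound to a double-bonded ring carbon, the same change, at the same place, that was seen between compound 1 and compound 2. On the strength of an at least 2.6-fold higher number from compound 1 to compound 2 (0.42 log units; beyond the scatter), compound 4 is expected to show a weaker cytotoxic effect than compound 3, with an expected step of a 3.6-fold higher number from compound 3 to compound 4 (0.55 log units; beyond the scatter). Compound 4 is therefore estimated at 40000 nM, with the expected range running from 15000 nM to 150000 nM, and a real chance that the assay again returns only a limit.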

Compound 4, half-maximal inhibitory concentration: 21800 nM
The estimate for compound 4 lay 1.8-fold (0.26 log units) above the measured number, and the stated range covers the measured number.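

In this assay the exchange of 4-chlorophenyl for 2-bromophenyl on the core of compound 3 comes out as a 1.9-fold higher number from compound 3 to compound 4 (0.29 log units; within the scatter), so on this core the exchange cannot be told apart from the spread of repeated measurements. This shows neither that the exchange carries over from one core to the other with its size intact nor that it fades on the second core: the same change on two cores in this assay, an at least 2.6-fold higher number (0.42 log units; beyond the scatter) from compound 1 to compound 2 and a 1.9-fold higher number (0.29 log units; within the scatter) from compound 3 to compound 4; the limit leaves it open whether they differ. Compound 2 gives > 50000 nM, which is a limit of the assay and not a number, so the earlier step is known only as a lower bound: the limit of > 50000 nM in this assay, at which 1 of the 4 values shown sits.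

The compounds shown leave open whether the step belongs to the change of halogen or to the change of its place on the phenyl ring, as the two always travel together here, and a 4-bromophenyl or a 2-chlorophenyl group on the same cores would be needed to pull them apart. They also leave open how a phenyl ring carrying a group of another kind, such as an amine or a carboxylic acid, would read in this assay on either core.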